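Pentyl in place of pentynyl: expected effect on cytotoxicity

The compounds below may be only part of what the source reports. "The series", "measured", "known", "first", "only" and "open" are said of these compounds alone.

Compound 1 `CCCCCCCC/C=C/c1cc2cn([C@H]3C[C@H](O)[C@@H](CO)O3)c(=O)nc2o1`: 230000 nM
Compound 2 `CCCC#Cc1ccc(-c2cc3cn([C@H]4C[C@H](O)[C@@H](CO)O4)c(=O)nc3o2)cn1`: > 50000 nM (a limit of the assay)
Compound 3 `CCCCCc1ccc(CCc2cc3cn([C@H]4C[C@H](O)[C@@H](CO)O4)c(=O)nc3o2)cc1`: > 470000 nM (a limit of the assay)

All three compounds were tested in an ADME assay on HEL cells (Homo sapiens) for cytotoxicity, with a stated time of 3 days; a lower number here means that less compound is tolerated, a higher number that more compound is tolerated. Compound 2 stands at a limit in this assay, (the limit of > 50000 nM in this assay, at which 1 of the 3 values shown sits), so its true value is not pinned down. Compound 3 also stands at a limit, (the limit of > 470000 nM in this assay, at which 1 of the 3 values shown sits). Within the data shown here, compound 1 is the only one with a number, 230000 nM.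

Compound 4 `CCCCCc1ccc(-c2cc3cn([C@H]4C[C@H](O)[C@@H](CO)O4)c(=O)nc3o2)cn1` differs from compound 2 in one place: pentyl in place of pent-1-yn-1-yl on an aromatic carbon. Among the measured compounds shown here, no measured pair shows this change, so its size is unknown. The step that the limit leaves unreadable from compound 2 to compound 4 is expected to stay within the scatter, with no clear direction. Compound 4 is therefore expected to give 150000 nM, within 50000 nM to 500000 nM, quite possibly again only as a limit.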

Compound 4, half-maximal cytotoxic concentration: > 50000 nM
Compound 4: a limit, no number; the forecaster's own chance of this, stated with the estimate: 60%; the middle value is on the limit's open side.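

Compound 2 and compound 4 both give only a limit and not a number, so the step between them cannot be read. Going by these compounds, whether pentyl in place of pent-1-yn-1-yl shifts cytotoxicity at all, and in which direction, stays open.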